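Ether Oxygen Within a Long Chain: Compound 3

The compounds below may be only part of what the source reports. "The series", "measured", "known", "first", "only" and "open" are said of these compounds alone.

Of the compounds shown here, two have been measured in an assay for inhibition of acyl-CoA:cholesterol acyltransferase (Oryctolagus cuniculus), using microsomes; a lower number here means a stronger inhibitor, a higher number a weaker inhibitor. Compound 1 `CCCCCCCCC(C)(C)C(=O)Nc1c(C)cc(C)c2c1OC(C)(C)C2` gives 140 nM. Compound 2 `CCCCCCCCCCOc1ccc(C(=O)Nc2c(C)cc(C)c3c2OC(C)(C)C3)cc1` gives 30 nM, the lowest of the two numbers, and its gap to compound 1 lies beyond the scatter. Compound 3 `CCCOCCCCCCOc1ccc(C(=O)Nc2c(C)cc(C)c3c2OC(C)(C)C3)cc1` has not yet been measured; it differs from compound 2 by propoxy in place of butyl on a saturated chain carbon, six bonds along the chain from an oxygen on an aromatic ring. Among the measured compounds shown here, no measured pair shows a change of this kind, so there is no direct precedent. Compound 3 is expected to give a somewhat higher number, a step of a 2.0-fold higher number from compound 2 to compound 3 (0.30 log units; within the scatter) that may well stay within the scatter. The estimate for compound 3 is 60 nM, ranging from 20 nM to 250 nM.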

Compound 3, half-maximal inhibitory concentration: > 200 nM
Compound 3 was reported as a limit (the forecaster's own chance of this, stated with the estimate: 3%); middle value at least 3.3-fold (0.52 log units) from the limit.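

Replacing butyl with propoxy on a saturated chain carbon, six bonds along the chain from an oxygen on an aromatic ring, leaves the group's heavy-atom count unchanged yet gives an at least 6.6-fold higher number from compound 2 to compound 3 (0.82 log units; beyond the scatter). So at this position, one oxygen in place of one carbon is enough to weaken inhibition, which the earlier compounds did not show. Compound 3 is reported only as a limit, > 200 nM. Going by these compounds, the full size of the loss remains unknown, as does whether an oxygen elsewhere along the chain would act alike. On these data alone, how an amine here or a longer all-carbon chain would behave also stays open.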